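Aryl amide series: 3-hydroxyphenyl to 2-fluorophenyl

The compounds below may be only part of what the source reports. "The series", "measured", "known", "first", "only" and "open" are said of these compounds alone.

Measured in a functional assay on NCI-H460 cells (Homo sapiens) for inhibition, read by CCK-8 assay, with a stated time of 72 h, tested at 10 uM; a higher number here means more inhibition of growth at the concentration tested, a lower number less inhibition of growth:
Compound 1 `CN(C)C(=O)c1cc2cnc(Nc3ccc(NC(=O)C4(C(=O)Nc5ccc(F)cc5)CC4)cc3)nc2n1C1CCCC1`: 102%
Compound 2 `CN(C)C(=O)c1cc2cnc(Nc3ccc(NC(=O)C4(C(=O)Nc5ccc(Cl)cc5)CC4)cc3)nc2n1C1CCCC1`: 95.7%
Compound 3 `CN(C)C(=O)c1cc2cnc(Nc3ccc(NC(=O)C4(C(=O)Nc5cccc(O)c5)CC4)cc3)nc2n1C1CCCC1`: 94.9%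

Compound 3 gives 94.9%, within the scatter of the other two compounds, so no order can be drawn among the three.

Compound 4 `CN(C)C(=O)c1cc2cnc(Nc3ccc(NC(=O)C4(C(=O)Nc5ccccc5F)CC4)cc3)nc2n1C1CCCC1` carries 2-fluorophenyl in place of 3-hydroxyphenyl on an amide-type nitrogen. Going by the values given here, three measured steps bear on this change. They are a number 7.1 percentage points lower from compound 1 to compound 3 (within the scatter), a number 0.8 percentage points lower from compound 2 to compound 3 (within the scatter) and, for the halogen exchange alone, a number 6.3 percentage points lower from compound 1 to compound 2 (within the scatter). All three changed the aryl group on the same amide-type nitrogen, and none left the scatter. Among the compounds with values here, no compound with 2-fluorophenyl has been measured, so that placement of the fluoro group remains untested, and the range is kept wider on the low side.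

A step of a number 1.1 percentage points higher from compound 3 to compound 4 (within the scatter) is expected in this assay, with no change beyond the scatter. The estimated value for compound 4 is 96%, with an expected range of 84% to 104%.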

Compound 4, percent growth inhibition at one concentration: 93.1%
For compound 4 the middle estimate is 2.9 percentage points above the measured one; low and high end bracket the measured number.
By their numbers in this assay, from the lowest: compounds 4, 3, 2 and 1 (each within the scatter of the next).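

In this assay, the fluoro group on the aryl ring of this amide-type nitrogen can now be compared in two placements, 4-fluorophenyl and 2-fluorophenyl, and the exchange reads as a number 8.9 percentage points lower from compound 1 to compound 4 (within the scatter). Exchanging 3-hydroxyphenyl for 2-fluorophenyl, which takes the counted hydrogen-bond donor and acceptor off this group, reads as a number 1.8 percentage points lower from compound 3 to compound 4 (within the scatter), and exchanging 4-chlorophenyl for 2-fluorophenyl reads as a number 2.6 percentage points lower from compound 2 to compound 4 (within the scatter), so these four substituted phenyl groups are not separated at this position. No supporting measurement bears on this result, so it stays a plain reading of growth inhibition.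

With all four compounds this close at a single concentration, any real differences among these aryl groups remain unresolved. Also open, from the compounds shown here alone, is whether a phenyl carrying an amine or a carboxylic acid, or a cyclohexyl group in place of the phenyl, would read outside the scatter on this nitrogen.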